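The source may report more compounds than this note shows. Statements on the series, on what has been measured and on what is new or still open speak of the compounds shown alone.

Of the compounds shown here, three built on one shared core have been tested in a functional assay on MCF7 cells (Homo sapiens) for antiproliferative activity, read by sulforhodamine B assay, with a stated time of 48 h; a higher number here means a weaker inhibitor of growth, a lower number a stronger inhibitor of growth. Compound 1 `COc1cc(Cn2cc(CNC(=O)c3cn(-c4ccccc4)nc3-c3ccc(Cl)cc3)nn2)cc(OC)c1` gives 150 nM in this assay. Compound 2 `COc1cc(Cn2cc(CNC(=O)c3cn(-c4ccccc4)nc3-c3ccc(Cl)cc3)nn2)cc(OC)c1OC` differs from it only by methoxy in place of hydrogen on an aromatic carbon, and in this assay compound 2 gives 2500 nM, a loss of potency seen as a 17-fold higher number from compound 1 to compound 2 (1.22 log units; beyond the scatter). Compound 3 `COc1ccc(-c2nn(-c3ccccc3)cc2C(=O)NCc2cn(Cc3cc(OC)cc(OC)c3)nn2)cc1` has a different core, the difference being (methoxy in place of chloro on an aromatic carbon); in this assay compound 3 gives 700 nM, which corresponds to a 4.7-fold higher number from compound 1 to compound 3 (0.67 log units; beyond the scatter).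

Compound 4 `COc1ccc(-c2nn(-c3ccccc3)cc2C(=O)NCc2cn(Cc3cc(OC)c(OC)c(OC)c3)nn2)cc1` has not yet been measured. Among the compounds with values here, it differs from compound 3 by methoxy in place of hydrogen on an aromatic carbon, which is the same change, at the same kind of place, as the one separating compound 1 from compound 2, now made on the core of compound 3. Within the data shown here, with only one earlier example of this change, the expectation rests on that single step. For compound 4 that change is expected to bring a 14-fold higher number from compound 3 to compound 4 (1.15 log units; beyond the scatter), because the same change gave a 17-fold higher number from compound 1 to compound 2 (1.22 log units; beyond the scatter). Compound 4 is therefore estimated to give around 10000 nM in this assay, most likely falling between 3000 nM and 35000 nM.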

Compound 4, concentration for 50% growth inhibition: 7600 nM
Estimate against measurement, compound 4: 1.3-fold (0.12 log units) above, within the range that was stated.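

Adding a methoxy group, which turns 3,5-dimethoxyphenyl into 3,4,5-trimethoxyphenyl, weakens growth inhibition in this assay to a similar degree on both cores, with an 11-fold higher number from compound 3 to compound 4 (1.04 log units; beyond the scatter) closely matching the earlier step: the same change on two cores in this assay, a 17-fold higher number (1.22 log units; beyond the scatter) from compound 1 to compound 2 and an 11-fold higher number (1.04 log units; beyond the scatter) from compound 3 to compound 4, 1.5-fold (0.19 log units) apart, within the scatter of two such steps

The change from chloro to methoxy carries over in the same way, with a 3.0-fold higher number from compound 2 to compound 4 (0.48 log units; beyond the scatter) on the trimethoxy side of the series: the same change on two cores in this assay, a 4.7-fold higher number (0.67 log units; beyond the scatter) from compound 1 to compound 3 and a 3.0-fold higher number (0.48 log units; beyond the scatter) from compound 2 to compound 4, 1.5-fold (0.19 log units) apart, within the scatter of two such steps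

Together these steps show that the two changes behave independently of each other in these four compounds, but each comparison rests on only one pair of steps, so they do not show that either change would carry over to a different core or why either change lowers potency.

The compounds shown leave open how a hydroxyl group, an amine or a longer chain such as ethoxy would behave in place of the added methoxy. They also leave open whether fluoro or a nitrile in place of chloro would follow the same pattern.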